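From a (tert-butyl)carbonyl group to an allyl group

The source may hold more compounds than are shown below. What is called first, only, known or untested is meant among the compounds shown, and "the series" means these compounds.

In an ADME assay on Huh-7 cells (Homo sapiens) for cytotoxicity, read by XTT assay (a lower number here means that less compound is tolerated, a higher number that more compound is tolerated), compound 1 (`O=C(OC[C@@H]1C[C@@H](O)[C@H](n2cnc3c(Cl)ncnc32)O1)c1ccccc1`) gives 70500 nM and compound 2 (`CC(C)(C)C(=O)OC[C@H]1O[C@@H](n2cnc3c(Cl)ncnc32)C[C@@H]1O`) gives 177000 nM as the higher of the two numbers, a gap beyond the usual scatter. Compound 3 (`C=CCOC[C@H]1O[C@@H](n2cnc3c(Cl)ncnc32)C[C@@H]1O`) carries allyl in place of (tert-butyl)carbonyl on an oxygen on a saturated carbon and has not yet been measured. Among the compounds with values here, no measured step shows what this change does, so only a small move toward a lower number, within the scatter, is expected: an estimated 1.5-fold lower number from compound 2 to compound 3 (0.17 log units; within the scatter) in this assay for this change. The value expected for compound 3 is 120000 nM with 45000 nM to 300000 nM as its range.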

Compound 3, half-maximal cytotoxic concentration: 140000 nM
The estimate for compound 3 lay 1.2-fold (0.07 log units) below the measured number; the range from low to high includes it.
By their numbers in this assay, from the lowest: compounds 1, 3 and 2 (each within the scatter of the next, the first and the last beyond it).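

In this assay, replacing (tert-butyl)carbonyl with allyl on this oxygen gives a 1.3-fold lower number from compound 2 to compound 3 (0.10 log units; within the scatter), so the two compounds cannot be told apart. At this position, then, an ester group of 6 heavy atoms with a hydrogen-bond acceptor and an ether-linked allyl group of 3 heavy atoms are tolerated alike. Nothing measured here explains this result. From the compounds shown here alone, whether the same holds for a much longer chain or an amine-bearing chain on this oxygen stays open. So does the effect of a free hydroxyl group there.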